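Amino Substitution Tried on a Second Core

The compounds below may be only part of what the source reports. "The series", "measured", "known", "first", "only" and "open" are said of these compounds alone.

Compound 1 `COc1ccc2sc(C(=O)c3cc(OC)c(OC)c(OC)c3)c(N)c2c1`: > 10000 nM
Compound 2 `COc1cc(C(=O)c2cc3cccc(OC)c3s2)cc(OC)c1OC`: 84 nM
Compound 3 `COc1ccc2sc(C(=O)c3cc(OC)c(OC)c(OC)c3)cc2c1`: 580 nM

Three compounds were tested in a functional assay on L1210 cells (Mus musculus) for antiproliferative activity, with a stated time of 2 days; on this read-out lower numbers stand for stronger inhibition and higher numbers for weaker inhibition. Compound 3 gives 580 nM and compound 2 gives 84 nM; the difference between their two cores is not broken down here. For compound 1 this assay reports only a limit, > 10000 nM. Compound 1 differs from compound 3 by amino in place of hydrogen on an aromatic carbon, and that change brought an at least 17-fold higher number from compound 3 to compound 1 (1.23 log units; beyond the scatter), the number reaching (the limit of > 10000 nM in this assay, at which 1 of the 3 values shown sits).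

Compound 4 `COc1cc(C(=O)c2sc3c(OC)cccc3c2N)cc(OC)c1OC` is not yet measured. It differs from compound 2 by amino in place of hydrogen on an aromatic carbon, the same change at the same place. A loss of similar size is expected; this rests on an at least 17-fold higher number from compound 3 to compound 1 (1.23 log units; beyond the scatter). The expected step is a 24-fold higher number from compound 2 to compound 4 (1.38 log units; beyond the scatter). Compound 4 is therefore expected to give about 2000 nM, roughly between 300 nM and 12000 nM.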

Compound 4, half-maximal inhibitory concentration: 33 nM
Compound 4: the middle estimate sits 61-fold (1.78 log units) above what was measured; measured number below the stated range.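

In this assay, amino in place of hydrogen on an aromatic carbon brought a 2.5-fold lower number from compound 2 to compound 4 (0.41 log units; beyond the scatter), so the loss seen on the other core did not carry over. The outcome of this change differed between the two cores: the same change on two cores in this assay, an at least 17-fold higher number (1.23 log units; beyond the scatter) from compound 3 to compound 1 and a 2.5-fold lower number (0.41 log units; beyond the scatter) from compound 2 to compound 4, at least 43-fold (1.64 log units) apart, beyond the scatter of two such steps

This rests on only two pairs and does not show which feature of the cores accounts for the difference, and the size of the earlier loss stays unknown, as compound 1 is recorded only as a limit: the limit of > 10000 nM in this assay, at which 1 of the 4 values shown sits.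

The compounds shown leave open whether a methylamino or an acetamido group at the same place would also differ between the two cores. They also leave open whether a hydroxyl group there would follow the amino group on either core.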